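The source may hold more compounds than are shown below. What is called first, only, known or untested is meant among the compounds shown, and "the series" means these compounds.

In an ADME assay on the whole organism with Oryza sativa as the target, tested at 1 uM (a higher number here means a weaker effect of the compound at the concentration tested, a lower number a stronger effect), compound 3 `CCCCCCCc1ccc(NC(=O)N[C@H](C)c2ccccc2)cc1` gives 100%, the second highest of the three numbers. Its nearest neighbour is compound 2 `CCCCCCc1ccc(NC(=O)N[C@H](C)c2ccccc2)cc1`, which gives 101%, and the difference a number 1 percentage points lower from compound 2 to compound 3 (within the scatter) lies within the scatter. Furthest away is compound 1 `CCCCc1ccc(NC(=O)N[C@H](C)c2ccccc2)cc1`, which gives 32%; the steps of a number 69 percentage points higher from compound 1 to compound 2 (beyond the scatter) and a number 68 percentage points higher from compound 1 to compound 3 (beyond the scatter) are both large. Compound 4 `CC(=O)c1ccc(NC(=O)N[C@H](C)c2ccccc2)cc1` differs from compound 3 by acetyl in place of heptyl on an aromatic carbon. For the measured compounds named here, no measured step covers this change: the measured steps only add ethyl, propyl or methyl on a saturated chain carbon, whereas here heptyl leaves and acetyl enters. The direction is therefore open, and compound 4 is expected to land between the extremes seen, with a number 50 percentage points lower from compound 3 to compound 4 (beyond the scatter) as the expected step. Compound 4 is estimated at 50%, in the range 15% to 100%.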

Compound 4, a percentage reported as activity, at one concentration (the size of the read-out at that concentration, not a potency): 93%
Beside the measured number, compound 4's estimate is 43 percentage points below it; the range from low to high includes it.
By their numbers in this assay, from the lowest: compound 1; then compounds 4, 3 and 2 (each within the scatter of the next).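

In this assay, acetyl on this aromatic carbon, para to a large group, cannot be told apart from the long chains: a number 7 percentage points lower from compound 3 to compound 4 (within the scatter) and a number 8 percentage points lower from compound 2 to compound 4 (within the scatter). Only butyl stands apart, with a number 61 percentage points higher from compound 1 to compound 4 (beyond the scatter), so a carbonyl-bearing group of 3 heavy atoms groups with heptyl of 7, and the number at this position does not follow heavy-atom count across these compounds, compound 1 being the one that goes against any such grouping. No measurement here explains why compound 1 differs.
Going by these compounds, whether propyl or pentyl chains group with butyl or with hexyl remains open, which leaves the edge of the change undefined. So does whether an amine or a carboxylic acid on this carbon would group with acetyl.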